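Swapping an ortho trifluoromethyl for fluoro on a benzamide

The source may report more compounds than this note shows. Statements on the series, on what has been measured and on what is new or still open speak of the compounds shown alone.

Compound 1 `O=C(Nc1nc(-c2ccccc2)nc2c1nnn2Cc1ccccc1)c1ccccc1C(F)(F)F`: 560 nM
Compound 2 `O=C(Nc1nc(-c2ccccc2)nc2c1nnn2Cc1ccccc1)c1cccc(C(F)(F)F)c1`: 2510 nM

Both compounds share one core and differ only in the group on the benzamide ring. In an assay on CHO cells for displacement of a labelled ligand from adenosine receptor A3 (Homo sapiens), read by scintillation counting (on this read-out lower numbers stand for stronger inhibition and higher numbers for weaker inhibition), compound 1 gives 560 nM, the lowest of the two numbers measured. Moving the trifluoromethyl from the 2-position to the 3-position gives a 4.5-fold higher number from compound 1 to compound 2 (0.65 log units; beyond the scatter), so compound 1 is the better starting point.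

Compound 3 `O=C(Nc1nc(-c2ccccc2)nc2c1nnn2Cc1ccccc1)c1ccccc1F` keeps the substituent at the same place but shrinks it: fluoro in place of trifluoromethyl on an aromatic carbon. Within the data shown here, none of the measured steps covers this kind of change; the single step from compound 1 to compound 2 concerns where the trifluoromethyl sits, not how large the group at that spot is. There is therefore no direct guide, and the expectation for compound 3 has to stay wide. Among the measured compounds shown here, a modest loss is taken as the central guess, since the only group tried at that place was the larger one, and the step is expected to be a 1.8-fold higher number from compound 1 to compound 3 (0.25 log units; within the scatter). Compound 3 is estimated at 1000 nM, with a range from 300 nM to 3500 nM.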

Compound 3, inhibition constant: 5300 nM
Beside the measured number, compound 3's estimate is 5.3-fold (0.72 log units) below it, and the stated range ends below it.
By their numbers in this assay, from the lowest: compound 1; then compound 2; then compound 3.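

With the place on the ring held fixed, replacing trifluoromethyl with fluoro gives a 9.5-fold higher number from compound 1 to compound 3 (0.98 log units; beyond the scatter) in this assay, so the identity of the group at this spot matters, and not only where the trifluoromethyl sits. The earlier pair showed only the effect of moving the trifluoromethyl, which gave a 4.5-fold higher number from compound 1 to compound 2 (0.65 log units; beyond the scatter) on the same read-out. The 2-fluorophenyl amide also trails the 3-(trifluoromethyl)phenyl amide, with a 2.1-fold higher number from compound 2 to compound 3 (0.32 log units; beyond the scatter), so among these three compounds the amide with 2-(trifluoromethyl)phenyl holds the lowest number and the one with 2-fluorophenyl the highest; no measurement at hand gives a cause for these differences.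

With only trifluoromethyl and fluoro shown at this place, it remains open whether a methyl, a chloro or a methoxy group there would land nearer compound 1 or nearer compound 3. Going by these compounds, it is also open how fluoro would behave at the place the trifluoromethyl occupies in compound 2, which would show whether the order of these two places holds for a group other than trifluoromethyl.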